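A few compounds are considered here, and "the series" means these few. Any claim that something is new, unique, unknown or untested is made for them only; others in the source may bear on it.

Among the measured compounds shown here, in an assay on HEK293 cells for positive allosteric modulation of metabotropic glutamate receptor 5 (Homo sapiens), read by FLIPR (a higher number here means that more compound is needed for the effect, a lower number that less compound is needed), compound 3 `CC1CCN(C(=O)N2CC(c3nc(-c4cccc(Cl)c4)no3)C2)CC1` gives 865 nM, one of only two numerical values obtained. Compound 1 `CC1CCC(C(=O)N2CC(c3nc(-c4cccc(Cl)c4)no3)C2)CC1` gives 1500 nM, and the step of a 1.7-fold lower number from compound 1 to compound 3 (0.24 log units; within the scatter) stays within the scatter, so the two compounds cannot be told apart on these numbers. Compound 2 `O=C(C1CCCO1)N1CC(c2nc(-c3cccc(Cl)c3)no2)C1` reaches only a limit, > 10000 nM; this is the limit of > 10000 nM in this assay, at which 1 of the 3 values shown sits. The steps of an at least 6.6-fold higher number from compound 1 to compound 2 (0.82 log units; beyond the scatter) and an at least 11-fold lower number from compound 2 to compound 3 (1.06 log units; beyond the scatter) are accordingly bounded on one side only.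

Compound 4 `O=C(C1CCC2(CCC2)CC1)N1CC(c2nc(-c3cccc(Cl)c3)no2)C1` carries a group of 9 heavy atoms (9 carbon; one four-membered non-aromatic ring of carbon only, one six-membered non-aromatic ring of carbon only) in place of a group of 7 heavy atoms (6 carbon, 1 nitrogen; one six-membered non-aromatic ring with 1 hetero atom), on a carbonyl carbon. For the measured compounds named here, two measured steps bear on this change. The step of a 1.7-fold lower number from compound 1 to compound 3 (0.24 log units; within the scatter) shows that an all-carbon six-membered ring and a nitrogen-containing six-membered ring on the carbonyl carbon give numbers within the scatter of each other. The step of an at least 6.6-fold higher number from compound 1 to compound 2 (0.82 log units; beyond the scatter) shows that exchanging the 4-methylcyclohexyl ring for an oxolan-2-yl ring moves the value to the limit. Going by the values given here, the group entering in compound 4 is all-carbon, like the 4-methylcyclohexyl of compound 1, and no measured compound tests a spiro carbocycle here. The expectation is therefore no step beyond the scatter, an estimated change of a 1.4-fold higher number from compound 3 to compound 4 (0.14 log units; within the scatter). Compound 4 is expected to give about 1200 nM, within a range from 400 nM to 4000 nM.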

Compound 4, half-maximal effective concentration: 1100 nM
Estimate against measurement, compound 4: 1.1-fold (0.04 log units) above, within the range that was stated.
By their numbers in this assay, from the lowest: compounds 3, 4 and 1 (each within the scatter of the next). At a limit, above all of these: compound 2.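

In this assay, the steps of a 1.3-fold higher number from compound 3 to compound 4 (0.10 log units; within the scatter) and a 1.4-fold lower number from compound 1 to compound 4 (0.13 log units; within the scatter) both lie within the scatter, so compounds 1, 3 and 4 cannot be told apart on these numbers. Among the compounds shown here, this extends what the earlier compounds showed: on a carbonyl carbon whose other neighbour is the amide-type nitrogen in a ring, a group of 9 heavy atoms with a four-membered and a six-membered carbon ring gives a value in the same range as the two groups of 7 heavy atoms. The step of an at least 9.0-fold lower number from compound 2 to compound 4 (0.95 log units; beyond the scatter) lies beyond the scatter but is bounded on one side only, since compound 2 stands at a limit of the assay: the limit of > 10000 nM in this assay, at which 1 of the 4 values shown sits.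

The compounds shown do not separate ring size from the ring oxygen in the loss seen with oxolan-2-yl, and a tetrahydropyran-4-yl or a cyclopentyl group on the same carbonyl carbon would bear on that question. They also leave open whether any group here can bring the number beyond the scatter of these three compounds, for example a morpholin-4-yl or a 4,4-difluoropiperidin-1-yl group.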